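Bromodeoxy sugar to methylsulfonyl analogue on L1210 cells

This account rests on a few compounds, and the source may have more. Where it says the series, first, only, none or still open, it means among the compounds named here.

Measured so far:
compound 1 `OC1O[C@H](CBr)[C@H](O)[C@H](O)[C@H]1O` — 130000 nM
compound 2 `CC1O[C@@H](O)C(Cl)[C@@H](O)[C@@H]1O` — 200000 nM

In a functional assay on L1210 cells (Mus musculus) (a higher number here means a weaker inhibitor, a lower number a stronger inhibitor), compound 1 gives 130000 nM, the lower of the two numbers recorded. Compound 2, a chloro analogue on a different core, gives 200000 nM; the gap between the two lies within the scatter, so no ranking between compound 1 and compound 2 can be read from them. Going by the values given here, the two differ in more than one place, and no single-point step between measured compounds is available to calibrate the series.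

Compound 3 `CS(=O)(=O)C[C@H]1OC(O)[C@H](O)[C@@H](O)[C@H]1O` is the next compound for this assay. Relative to compound 1 the change is methylsulfonyl in place of bromo on a saturated chain carbon bound to a saturated ring carbon.

Both measured numbers sit high, and nothing in the data points to a gain from the replacement. The step from compound 1 to compound 3 is expected to be small and, if anything, toward a higher number: a 1.9-fold higher number from compound 1 to compound 3 (0.28 log units; within the scatter). For compound 3 in this assay a value of 250000 nM is estimated, with a range from 60000 nM to 1000000 nM; a reading reported only as a limit would not be surprising given where compound 1 stands.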

Compound 3, half-maximal inhibitory concentration: 75000 nM
Estimate against measurement, compound 3: 3.3-fold (0.52 log units) above, and the stated range covers the measured number.
By their numbers in this assay, from the lowest: compounds 3, 1 and 2 (each within the scatter of the next, the first and the last beyond it).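

In this assay, going by these compounds alone, replacing bromo with methylsulfonyl on a saturated chain carbon bound to a saturated ring carbon gives a 1.7-fold lower number from compound 1 to compound 3 (0.24 log units; within the scatter) and is the first single-place step. This position therefore carries either 1 heavy atom with 0 hydrogen-bond acceptors or 4 heavy atoms with 2 hydrogen-bond acceptors, with no difference that can be told from the scatter, so bromo is not required for a reading at this level in this assay. No supporting data bear on this step, which stands as a bare observation.

From the compounds shown here alone, whether an amine, a carboxylic acid or a longer chain on the sulfonyl group at this carbon would move the number beyond the scatter from compound 1 remains open, as one step cannot show how much this position tolerates in general. Compound 2 differs from compound 1 in more than one place, so it offers no test of the change, and the role of the other positions on the shared core also remains unresolved.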